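From Isobutylcarbonyloxy to Fluoro on a Shared Core

A few compounds are considered here, and "the series" means these few. Any claim that something is new, unique, unknown or untested is made for them only; others in the source may bear on it.

- Compound 1 `CCOc1ccc2oc(/C=C/[S+](C)[O-])cc(=O)c2c1`: 4900 nM
- Compound 2 `CC(=O)Oc1ccc2oc(/C=C/[S+](C)[O-])cc(=O)c2c1`: > 10000 nM (a limit of the assay, not a number)
- Compound 3 `CC(C)CC(=O)Oc1ccc2oc(/C=C/[S+](C)[O-])cc(=O)c2c1`: 6100 nM

In a functional assay on DLD-1 cells (Homo sapiens) for cytotoxicity, with a stated time of 48 h (on this read-out higher numbers stand for weaker inhibition and lower numbers for stronger inhibition), compound 3 gives 6100 nM, which lies within the scatter of compound 1: a 1.2-fold higher number from compound 1 to compound 3 (0.10 log units; within the scatter). Compound 2 gives only a limit, > 10000 nM.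

The next compound is compound 4 `C[S+]([O-])/C=C/c1cc(=O)c2cc(F)ccc2o1`, with fluoro in place of (isobutylcarbonyl)oxy on an aromatic carbon. The measured steps only exchange the group on the oxygen. Besides the step above, they are an at least 2.0-fold higher number from compound 1 to compound 2 (0.30 log units; that floor lies within the scatter) and an at least 1.6-fold lower number from compound 2 to compound 3 (0.21 log units; that floor lies within the scatter), and both of these rest on the limit. None of them replaces the oxygen with fluoro, so they are only a loose guide.

For the measured compounds named here, compound 3 at 6100 nM is the starting point, and since no measured step clearly exceeds the scatter, no change beyond the scatter is expected in this assay. The expected step is a 1.1-fold higher number from compound 3 to compound 4 (0.03 log units; within the scatter). Compound 4 is estimated at 6500 nM, with an expected range of 2500 nM to 17000 nM.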

Compound 4, half-maximal inhibitory concentration: 7000 nM
Compound 4: the middle estimate sits 1.1-fold (0.03 log units) below what was measured; the range from low to high includes it.
By their numbers in this assay, from the lowest: compounds 1, 3 and 4 (each within the scatter of the next). At a limit, above all of these: compound 2.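

Fluoro on this aromatic carbon puts no oxygen there at all, yet in this assay it reads the same as the oxygen-linked groups of the other two compounds with numbers (a 1.1-fold higher number from compound 3 to compound 4 (0.06 log units; within the scatter)) and (a 1.4-fold higher number from compound 1 to compound 4 (0.15 log units; within the scatter)). A single fluorine atom can therefore stand in for (isobutylcarbonyl)oxy, with its 7 heavy atoms, or for ethoxy with no change beyond the scatter, so among these compounds an oxygen at this position is not needed for the cytotoxicity seen. Compound 2 is known only as a limit of the assay, not a number, and the floor of its step (an at least 1.4-fold lower number from compound 2 to compound 4 (0.15 log units; that floor lies within the scatter)) lies within the scatter: the limit of > 10000 nM in this assay, at which 1 of the 4 values shown sits.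

As far as these compounds go, compounds 1, 3 and 4 all lie within the scatter of one another, so it stays open whether this position can shift the read-out at all. From the compounds shown here alone, what an amine or a carboxylic acid on this aromatic carbon would give also remains open.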